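A few compounds are considered here, and "the series" means these few. Any claim that something is new, unique, unknown or untested is made for them only; others in the source may bear on it.

Measured compounds:
compound 1 `COc1cccc(/C=C/C(=O)c2c(OC)cc(OC)c(CC=C(C)C)c2O)c1` — 49200 nM
compound 2 `COc1cc(OC)c(C(=O)/C=C/c2ccc(N3CCN(C(=O)OC(C)(C)C)CC3)cc2)c(O)c1CC=C(C)C` — > 100000 nM

Within the data shown here, in an ADME assay on MCF7-DOX cells (Homo sapiens) for cytotoxicity, read by MTT assay, with a stated time of 48 h (on this read-out higher numbers stand for weaker inhibition and lower numbers for stronger inhibition), compound 1 gives 49200 nM, the only plain number among the two values shown. For compound 2 the result in this assay is a limit of the assay, not a number: > 100000 nM, as noted (the limit of > 100000 nM in this assay, at which 1 of the 2 values shown sits). Compound 3 `COc1ccc(/C=C/C(=O)c2c(OC)cc(OC)c(CC=C(C)C)c2O)cc1` has not yet been measured. It differs from compound 1 by 4-methoxyphenyl in place of 3-methoxyphenyl on a double-bonded chain carbon bound to a double-bonded chain carbon. Among the measured compounds shown here, no measured step of this kind is available, so the change is expected to fall within the usual scatter, with no clear direction, and the expected step of a 1.2-fold lower number from compound 1 to compound 3 (0.09 log units; within the scatter) is small. Compound 3 is expected to give about 40000 nM, within a range from 15000 nM to 120000 nM.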

Compound 3, half-maximal inhibitory concentration: 46900 nM
For compound 3 the middle estimate is 1.2-fold (0.07 log units) below the measured one; low and high end bracket the measured number.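

In this assay, 4-methoxyphenyl in place of 3-methoxyphenyl gives a 1.0-fold lower number from compound 1 to compound 3 (0.02 log units; within the scatter), so the two groups cannot be told apart here. Among these compounds, this is the first measured step at this position on the chain, and it shows that the same atoms, joined differently, can leave two readings within the scatter of each other. Nothing measured here offers an explanation for this result. The compounds shown leave open whether a different group at this place, such as an amine or a carboxylic acid, would move the number beyond the scatter.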